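This account rests on a few compounds, and the source may have more. Where it says the series, first, only, none or still open, it means among the compounds named here.

Compound 1 `CN(C)CCCNc1nc(-c2ccc(NC(=O)Nc3ccccc3Cl)cc2)nc2ccsc12` is the reference point; in a functional assay on HT-29 cells (Homo sapiens) for cytotoxicity, read by MTT assay, with a stated time of 72 h (on this read-out higher numbers stand for weaker inhibition and lower numbers for stronger inhibition), compound 1 gives 390 nM. Among the measured compounds shown here, compound 2 `CN(C)CCCNc1nc(-c2ccc(NC(=O)Nc3ccc(Cl)cc3Cl)cc2)nc2ccsc12` carries a single change, (chloro in place of hydrogen on an aromatic carbon), and in this assay compound 2 gives 1860 nM, so that the step of a 4.8-fold higher number from compound 1 to compound 2 (0.68 log units; beyond the scatter) is the only measured instance of this change. Compound 3 `CN(C)CCCNc1nc(-c2ccc(NC(=O)Nc3ccccc3Cl)cc2)nc2c(Cl)c(Cl)sc12` keeps the same aryl urea portion but differs from compound 1 in its core, a difference that is not broken down here; in this assay compound 3 gives 820 nM. Compound 4 `CN(C)CCCNc1nc(-c2ccc(NC(=O)Nc3ccc(Cl)cc3Cl)cc2)nc2c(Cl)c(Cl)sc12` is not yet measured and stands to compound 3 as compound 2 stands to compound 1, through (chloro in place of hydrogen on an aromatic carbon), at the same place. For the measured compounds named here, it is expected that the step of a 4.3-fold higher number from compound 3 to compound 4 (0.63 log units; beyond the scatter) will be of similar size to the earlier one, because the sole precedent is a 4.8-fold higher number from compound 1 to compound 2 (0.68 log units; beyond the scatter). On that basis compound 4 is expected to give about 3500 nM in this assay, likely between 1200 nM and 10000 nM.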

Compound 4, half-maximal inhibitory concentration: 1320 nM
Estimate against measurement, compound 4: 2.7-fold (0.42 log units) above, and the stated range covers the measured number.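

On the core of compound 3, chloro in place of hydrogen gives a 1.6-fold higher number from compound 3 to compound 4 (0.21 log units; within the scatter) in this assay, a step that does not separate the two compounds. The change therefore did not carry over at the same size from one core to the other: the same change on two cores in this assay, a 4.8-fold higher number (0.68 log units; beyond the scatter) from compound 1 to compound 2 and a 1.6-fold higher number (0.21 log units; within the scatter) from compound 3 to compound 4, 3.0-fold (0.47 log units) apart, beyond the scatter of two such steps. With one pair on each core, this shows that the step cannot be assumed to transfer unchanged between these two cores, but it does not show why the steps differ or what would happen on any other core.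

The compounds shown leave open whether a fluoro or methoxy group in place of the added chloro would also give different steps on the two cores. They also leave open whether the gap would persist with a longer chain in place of the dimethylamino side chain.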